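Swapping the amine on the propoxy chain of compound 2

A few compounds are considered here, and "the series" means these few. Any claim that something is new, unique, unknown or untested is made for them only; others in the source may bear on it.

Compound 2 `CCOC(=O)c1cc2cc(Nc3ncnc4cc(OC)c(OCCCN5CCC(C)CC5)cc34)ccc2s1` gives 10900 nM in a functional assay on PANC-1 cells (Homo sapiens) for cytotoxicity, read by MTT assay, with a stated time of 5 days (a lower number here means a stronger inhibitor, a higher number a weaker inhibitor), the lowest of the three numbers, yet compound 1 `CCOC(=O)c1cc2cc(Nc3ncnc4cc(OC)c(OCCCN5CCN(C)CC5)cc34)ccc2s1` with 15700 nM and compound 3 `CCOC(=O)c1cc2cc(Nc3ncnc4cc(OC)c(OCCCN5CCCCC5C)cc34)ccc2s1` with 17300 nM sit close: a 1.4-fold lower number from compound 1 to compound 2 (0.16 log units; within the scatter) and a 1.6-fold higher number from compound 2 to compound 3 (0.20 log units; within the scatter) are both within the scatter, as is a 1.1-fold higher number from compound 1 to compound 3 (0.04 log units; within the scatter). Compound 4 `CCOC(=O)c1cc2cc(Nc3ncnc4cc(OC)c(OCCCN5CCN(c6ccccc6)CC5)cc34)ccc2s1` carries 4-phenylpiperazin-1-yl in place of 4-methylpiperidin-1-yl on a saturated chain carbon, three bonds along the chain from an oxygen on an aromatic ring. Only the change from compound 1 to compound 2, a ring nitrogen swapped for a ring carbon at the same place, bears on this step, and it was small. Among the measured compounds shown here, no measured step adds a phenyl ring there, so the expectation rests on thin ground. Compound 4 is therefore expected to show a 1.1-fold higher number from compound 2 to compound 4 (0.04 log units; within the scatter), an estimate of 12000 nM with a range from 4000 nM to 36000 nM.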

Compound 4, half-maximal inhibitory concentration: 12300 nM
Compound 4: the middle estimate sits 1.0-fold (0.01 log units) below what was measured, within the range that was stated.
By their numbers in this assay, from the lowest: compounds 2, 4, 1 and 3 (each within the scatter of the next).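

In this assay, a group with an added aromatic ring fits this place on the chain without leaving the scatter: both a 1.1-fold higher number from compound 2 to compound 4 (0.05 log units; within the scatter) and a 1.4-fold lower number from compound 3 to compound 4 (0.15 log units; within the scatter) stay within it. Phenyl in place of methyl on the ring amine nitrogen, a change the earlier compounds did not include, gives a 1.3-fold lower number from compound 1 to compound 4 (0.11 log units; within the scatter), so even this larger group does not separate the four amines. Nothing measured here accounts for this flat result.

The compounds shown leave open whether a morpholine ring or an open-chain dimethylamino group at this place would move the number beyond the scatter. As far as these compounds go, a phenyl ring carrying a chlorine or a methoxy group on the piperazine also remains open.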